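Fluoro in Place of Nitro on an Aromatic Carbon

This account rests on a few compounds, and the source may have more. Where it says the series, first, only, none or still open, it means among the compounds named here.

In a functional assay on MDA-MB-231 cells (Homo sapiens) for inhibition, read by MTT assay, with a stated time of 72 h (a lower number here means a stronger inhibitor, a higher number a weaker inhibitor), compound 2 `O=C(NO)c1ccc(CNCc2nc(-c3ccc([N+](=O)[O-])cc3)no2)cc1` gives 9560 nM and compound 1 `O=C(NO)c1ccc(CNCc2nc(-c3ccccc3)no2)cc1` gives 14700 nM, so the two numbers lie within the scatter of each other. Compound 3 `O=C(NO)c1ccc(CNCc2nc(-c3ccc(F)cc3)no2)cc1` keeps the shared core but carries fluoro in place of nitro on an aromatic carbon, para to a large group fluoro in place of nitro on an aromatic carbon at this same place. Within the data shown here, only one measured step bears on this change, a 1.5-fold lower number from compound 1 to compound 2 (0.19 log units; within the scatter), and it introduced nitro in place of hydrogen. Among the measured compounds shown here, no fluoro compound has yet been measured, so the comparison is indirect. With that single step as the guide, no change beyond the scatter is expected in this assay. The expected size is a 1.3-fold higher number from compound 2 to compound 3 (0.10 log units; within the scatter), a step that would stay within the scatter. The estimated value for compound 3 is 12000 nM, with an expected range of 6000 nM to 24000 nM.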

Compound 3, half-maximal inhibitory concentration: 9120 nM
Compound 3: the middle estimate sits 1.3-fold (0.12 log units) above what was measured, within the range that was stated.
By their numbers in this assay, from the lowest: compounds 3, 2 and 1 (each within the scatter of the next).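

Fluoro in place of nitro on this aromatic carbon, para to a large group, leaves the result in this assay essentially where it was (a 1.0-fold lower number from compound 2 to compound 3 (0.02 log units; within the scatter)), and fluoro in place of hydrogen also stays inside the scatter (a 1.6-fold lower number from compound 1 to compound 3 (0.21 log units; within the scatter)). With a second substituent now measured at this place, all three compounds lie within the scatter of one another, so neither nitro nor fluoro separates from hydrogen here. Nothing measured here accounts for how close these numbers lie.

The compounds shown leave open whether any group on this aromatic carbon can move the number beyond the scatter, as only hydrogen, nitro and fluoro appear there. An amine, a carboxylic acid or a longer chain at this place remains untested among these compounds, and so does any change elsewhere on the shared core.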